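The source may hold more compounds than are shown below. What is called first, only, known or untested is meant among the compounds shown, and "the series" means these compounds.

Measured so far:
Compound 1 `O=C(O)CC(NS(=O)(=O)c1cc(F)cc(F)c1)c1ccccc1`: 79300 nM
Compound 2 `O=C(O)CC(NS(=O)(=O)c1ccccc1)c1ccccc1F`: > 100000 nM, a limit of the assay and not a number
Compound 3 `N#Cc1ccc(S(=O)(=O)NC(CC(=O)O)c2ccccc2F)cc1`: 69700 nM

In a functional assay on MDA-MB-231 cells (Homo sapiens) for antiproliferative activity, read by MTT assay, with a stated time of 24 h (on this read-out higher numbers stand for weaker inhibition and lower numbers for stronger inhibition), compound 3 and compound 1 lie within the scatter of each other, so neither can be ranked ahead. Compound 4 `O=C(O)CC(NS(=O)(=O)c1cc(F)cc(F)c1)c1ccccc1F` differs from compound 3 on the sulfonyl sulfur, with 3,5-difluorophenyl in place of 4-cyanophenyl (3,5-difluorophenyl in place of 4-cyanophenyl on a sulfonyl sulfur). Within the data shown here, the only measured step in this small set is an at least 1.4-fold lower number from compound 2 to compound 3 (0.15 log units; that floor lies within the scatter), and it starts from a limit, so it gives only a floor. It does not involve the 3,5-difluorophenyl group. More useful is compound 1, which carries that group on the sulfonyl sulfur and gives 79300 nM. No change beyond the scatter is therefore expected, and the estimated step is a 1.0-fold higher number from compound 3 to compound 4 (0.01 log units; within the scatter). For compound 4 the expected value is 72000 nM, with an estimated range of 40000 nM to 125000 nM.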

Compound 4, half-maximal inhibitory concentration: 73500 nM
Beside the measured number, compound 4's estimate is 1.0-fold (0.01 log units) below it; measured number inside the range.
By their numbers in this assay, from the lowest: compounds 3, 4 and 1 (each within the scatter of the next). At a limit, above all of these: compound 2.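

In this assay, the step at the sulfonyl sulfur is a 1.1-fold higher number from compound 3 to compound 4 (0.02 log units; within the scatter), so 3,5-difluorophenyl and 4-cyanophenyl cannot be told apart at this position. Adding fluoro to an aromatic carbon gives a 1.1-fold lower number from compound 1 to compound 4 (0.03 log units; within the scatter), so this change cannot be told from the scatter either. The step of an at least 1.3-fold lower number from compound 2 to compound 4 (0.13 log units; that floor lies within the scatter) starts from a limit of the assay, so it gives only a floor and does not separate 3,5-difluorophenyl from phenyl. Going by these compounds, whether an amine or a longer chain on the sulfonyl sulfur would give a step beyond the scatter remains open.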